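Adding a 2-fluorophenyl to the indole nitrogen

A few compounds are considered here, and "the series" means these few. Any claim that something is new, unique, unknown or untested is made for them only; others in the source may bear on it.

Measured compounds:
- compound 1 `CC(C)N1CCN(CCN2CCC(c3cn(-c4ccc(F)cc4)c4cc(C(F)(F)F)ccc34)CC2)C1=O`: 91 nM
- compound 2 `Cc1ccc2c(C3CCN(CCN4CCN(C(C)C)C4=O)CC3)c[nH]c2c1`: 27 nM
- compound 3 `CC(C)N1CCN(CCN2CCC(c3c[nH]c4cc(Cl)ccc34)CC2)C1=O`: 34 nM

In an assay on cell membranes for displacement of a labelled ligand from Adrenergic receptor alpha-1 (Rattus norvegicus) (on this read-out higher numbers stand for weaker inhibition and lower numbers for stronger inhibition), compound 3 gives 34 nM. It sits second highest among the three numbers: compound 2 with 27 nM lies within the scatter of it, while compound 1 with 91 nM is clearly higher. For the measured compounds named here, the only single-point step known is a 1.3-fold higher number from compound 2 to compound 3 (0.10 log units; within the scatter), which changes nothing of note.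

Compound 4 `CC(C)N1CCN(CCN2CCC(c3cn(-c4ccccc4F)c4cc(Cl)ccc34)CC2)C1=O` differs from compound 3 by 2-fluorophenyl in place of hydrogen on an aromatic nitrogen. Going by the values given here, no measured step isolates this change. Compound 1 carries an aryl group on the same nitrogen, but it also differs from compound 3 on the aromatic carbon, so its higher number cannot be credited to the aryl group alone. The step of a 1.3-fold higher number from compound 2 to compound 3 (0.10 log units; within the scatter) concerns the carbon substituent and does not bear on the nitrogen.

Given the higher number of compound 1, compound 4 is expected to move upward by a 1.9-fold higher number from compound 3 to compound 4 (0.28 log units; within the scatter), a modest rise. The estimate for compound 4 is 65 nM, within a range of 25 nM to 170 nM.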

Compound 4, half-maximal inhibitory concentration: 120 nM
Estimate against measurement, compound 4: 1.8-fold (0.27 log units) below, within the range that was stated.
By their numbers in this assay, from the lowest: compounds 2 and 3 (each within the scatter of the next); then compounds 1 and 4 (each within the scatter of the next).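

Placing a 2-fluorophenyl on the aromatic nitrogen in place of hydrogen gives, in this assay, a 3.5-fold higher number from compound 3 to compound 4 (0.55 log units; beyond the scatter). For the compounds shown here, this is the first step that changes this nitrogen alone, so the weaker inhibition can be assigned to the new group, which compound 1 could not show since it also differs on an aromatic carbon. No measurement here explains why this aryl group weakens inhibition.

The compounds shown do not tell whether the rise comes from the six-membered aromatic ring itself or from its fluorine, and a plain phenyl on the same nitrogen would separate the two. On these data alone, it also remains open how a small group such as methyl, or a chain ending in an amine, would behave at this nitrogen on the same core.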